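Solubility Limits for Two Amines and a Piperidine Analogue

The source may report more compounds than this note shows. Statements on the series, on what has been measured and on what is new or still open speak of the compounds shown alone.

Compound 1 `[O-][n+]1nc(NCCN2CCCCC2)[n+]([O-])c2ccccc21`: > 49000000 nM
Compound 2 `CCN(CC)CCNc1n[n+]([O-])c2ccc(C)cc2[n+]1[O-]`: > 49000000 nM

In a physicochemical assay for solubility, in the presence of a further agent that is not named here (on this read-out lower numbers stand for lower solubility and higher numbers for higher solubility), compound 1 gives > 49000000 nM, which is a limit of the assay and not a number. In this assay compound 2 likewise gives > 49000000 nM, again a limit. Compound 2 therefore stands at the limit of > 49000000 nM in this assay, at which 2 of the 2 values shown sit. Compound 3 `Cc1ccc2c(c1)[n+]([O-])c(NCCN1CCCCC1)n[n+]2[O-]` differs from compound 2 by piperidin-1-yl in place of diethylamino on a saturated chain carbon, two bonds along the chain from a nitrogen on an aromatic ring. Going by the values given here, no step between measured compounds is available here. The estimated step from compound 2 to compound 3 is a step that the limit leaves unreadable from compound 2 to compound 3, expected to be none beyond the scatter. Compound 3 is expected to give 60000000 nM in this assay, estimated between 25000000 nM and 150000000 nM.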

Compound 3, solubility: 45000000 nM
The estimate for compound 3 lay 1.3-fold (0.12 log units) above the measured number; measured number inside the range.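

In this assay compound 3 is the only one of the three to give a number and not a limit, and that number puts a floor under each change. Piperidin-1-yl in place of diethylamino on the saturated chain carbon gives an at least 1.0-fold lower number from compound 2 to compound 3 (0.03 log units; that floor lies within the scatter) and methyl in place of hydrogen on an aromatic carbon gives an at least 1.0-fold lower number from compound 1 to compound 3 (0.03 log units; that floor lies within the scatter). Neither floor shows a change beyond the scatter, and the full size of both steps stays unread: the limit of > 49000000 nM in this assay, at which 2 of the 3 values shown sit.

Still open, from the compounds shown here alone, is how a morpholin-4-yl group in place of piperidin-1-yl, or a longer chain, would read in this assay.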